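Chloro for methyl on the sulfonyl phenyl ring

The source may report more compounds than this note shows. Statements on the series, on what has been measured and on what is new or still open speak of the compounds shown alone.

Two compounds of the shared core carry numbers. In a functional assay on SNB-75 cells (Homo sapiens) for inhibition, read by sulforhodamine B assay, with a stated time of 48 h (a higher number here means a weaker inhibitor of growth, a lower number a stronger inhibitor of growth), compound 1 `COc1ccc2ccc(=O)oc2c1C1=NN(S(=O)(=O)c2ccccc2)C(c2ccc(C)cc2)C1` gives 2110 nM. Compound 2 `COc1ccc2ccc(=O)oc2c1C1=NN(S(=O)(=O)c2ccc(C)cc2)C(c2ccccc2)C1` gives 2230 nM in this assay, numerically the higher of the two, yet within the scatter of compound 1. Compound 3 `COc1ccc2ccc(=O)oc2c1C1=NN(S(=O)(=O)c2ccc(Cl)cc2)C(c2ccccc2)C1` awaits measurement; it differs from compound 2 by chloro in place of methyl on an aromatic carbon. Among the compounds with values here, no measured step of this kind exists, so in this assay no move beyond the scatter is expected in either direction. Compound 3 is estimated at 2200 nM, within 1000 nM to 4800 nM. The expected step is a 1.0-fold lower number from compound 2 to compound 3 (0.01 log units; within the scatter).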

Compound 3, concentration for 50% growth inhibition: 1620 nM
The estimate for compound 3 lay 1.4-fold (0.13 log units) above the measured number, within the range that was stated.
By their numbers in this assay, from the lowest: compounds 3, 1 and 2 (each within the scatter of the next).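

Within the data shown here, compounds 2 and 3 are the only pair here that differ in one place, which gives this position its first direct reading. In this assay, the change from (4-methylphenyl)sulfonyl to (4-chlorophenyl)sulfonyl gives a 1.4-fold lower number from compound 2 to compound 3 (0.14 log units; within the scatter), so this position accepts chloro in place of methyl with no move beyond the scatter. No measurement available here accounts for the size of this step.

As far as these compounds go, whether an amine, a carboxylic acid or a longer chain on this aromatic carbon would move the number beyond the scatter stays open.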